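The source may hold more compounds than are shown below. What is called first, only, known or untested is meant among the compounds shown, and "the series" means these compounds.

Measured so far:
Compound 1, `CC(C)[C@H](N)CN(C(=O)[C@@H]1C[C@H]1c1ccccc1)c1ccc(-c2ccccc2)cc1`: 1.1 nM
Compound 2, `CC[C@H](C)[C@H](N)CN(C(=O)[C@@H]1C[C@H]1c1cccc(F)c1)c1ccc(-c2ccccc2)cc1`: 560 nM

Both compounds were tested in a functional assay for agonist activity at G protein-coupled receptor 88 (Homo sapiens), read by HTRF and cAMP accumulation; on this read-out higher numbers stand for an effect only at larger amounts of compound and lower numbers for an effect already at smaller amounts. In this assay compound 1 gives 1.1 nM, while compound 2 gives 560 nM, the higher of the two numbers by a margin that lies well beyond the usual scatter, so compound 2 needs far more material than compound 1 to reach the same effect. The two compounds differ in more than one place, so no single change can be credited for that gap.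

Compound 3, `CC[C@H](C)[C@H](N)CN(C(=O)[C@@H]1C[C@H]1c1cccs1)c1ccc(-c2ccccc2)cc1`, is not yet measured. It is built from compound 2 by one change: thiophen-2-yl in place of 3-fluorophenyl on a saturated ring carbon. The rest of the molecule is kept as in compound 2. Going by the values given here, no measured pair shows what swapping the group on the saturated ring carbon does here, so the expectation rests on compound 2 alone. A step of modest size in either direction, possibly within the scatter, seems most likely. For compound 3 the estimate is 450 nM, with a range from 120 nM to 1800 nM, meaning an expected step of a 1.2-fold lower number from compound 2 to compound 3 (0.09 log units; within the scatter).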

Compound 3, half-maximal effective concentration: 360 nM
Beside the measured number, compound 3's estimate is 1.3-fold (0.10 log units) above it; the measured number falls inside the stated range.
By their numbers in this assay, from the lowest: compound 1; then compounds 3 and 2 (each within the scatter of the next).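

In this assay, putting thiophen-2-yl in place of 3-fluorophenyl on the saturated ring carbon of the three-membered ring gives a 1.6-fold lower number from compound 2 to compound 3 (0.19 log units; within the scatter). Going by these compounds alone, this is the first step that isolates a single place, and it shows that, on this background, a six-membered aromatic ring of carbon only bearing fluorine and a smaller five-membered aromatic ring with sulfur as its hetero atom cannot be told apart in this read-out. The swap therefore neither costs nor gains a measurable effect here, although this one pair says nothing about other groups at this place, and nothing available explains the result.

The step also leaves the large gap between compound 1 and compound 2 unassigned, since those two differ in more than one place and a plain phenyl on the background of compound 2 would be needed to separate the contributions. Going by these compounds, it remains open how this place responds to groups of a different kind, such as a pyridin-2-yl ring, a saturated cyclohexyl ring or a simple methyl group.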